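Adding a methoxy group beside the phenol of compound 1

The source may report more compounds than this note shows. Statements on the series, on what has been measured and on what is new or still open speak of the compounds shown alone.

Compound 1 `CC1=CC[C@H](C(C)(C)NC(=S)N/N=C/c2ccc(O)cc2)CC1`: > 100000 nM, a limit of the assay
Compound 2 `CC1=CC[C@H](C(C)(C)NC(=S)N/N=C/c2ccc(N(C)C)cc2)CC1`: 45100 nM

In a functional assay on UACC-62 cells (Homo sapiens) for inhibition, read by sulforhodamine B assay, with a stated time of 48 h (a lower number here means a stronger inhibitor of growth, a higher number a weaker inhibitor of growth), compound 1 gives > 100000 nM, which is a limit of the assay and not a number. Compound 1 therefore stands only at the limit of > 100000 nM in this assay, at which 1 of the 2 values shown sits. Among the measured compounds shown here, the one measured step, an at least 2.2-fold lower number from compound 1 to compound 2 (0.34 log units; beyond the scatter), concerns a different group and bears on the present change only loosely. Compound 3 `COc1cc(/C=N/NC(=S)NC(C)(C)[C@H]2CC=C(C)CC2)ccc1O` differs from compound 1 by methoxy in place of hydrogen on an aromatic carbon. For the measured compounds named here, with no measured step covering this change, compound 3 is expected to remain near the limit, with a number no higher from compound 1 to compound 3 (the limit leaves the size open) expected. Compound 3 is estimated at 100000 nM, within 30000 nM to 300000 nM.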

Compound 3, concentration for 50% growth inhibition: 14700 nM
Estimate against measurement, compound 3: 6.8-fold (0.83 log units) above, and the stated range ends above it.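

In this assay, methoxy in place of hydrogen, ortho to a hydroxy group, gives an at least 6.8-fold lower number from compound 1 to compound 3 (0.83 log units; beyond the scatter), so this place on the aromatic ring can carry a group and still leave a measurable number. The full size of the step cannot be read because compound 1 stands only at a limit: the limit of > 100000 nM in this assay, at which 1 of the 3 values shown sits. The compounds shown leave open whether an ethoxy group, a chlorine atom or a second hydroxy group in this place would give a similar step, and whether methoxy would do so without the neighbouring hydroxy group.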